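Iodine to Bromine on the Aryl Ring of a Cinnamoyl Triketone

The source may hold more compounds than are shown below. What is called first, only, known or untested is meant among the compounds shown, and "the series" means these compounds.

Measured compounds:
compound 1 `CCCC1(CC=C(C)C)C(=O)C(C(=O)/C=C/c2ccccc2)=C(O)C(CCC)(CCC)C1=O` gives 8.4 uM
compound 2 `CCCC1=C(OC)C(CCC)(CCC)C(=O)/C(=C(O)\C=C\c2ccc(I)cc2)C1=O` gives 2.8 uM
compound 3 `COC1=C(CC(C)C)C(=O)/C(=C(O)/C=C/c2ccccc2)C(=O)C1(CC(C)C)CC(C)C` gives 12.4 uM

All three compounds were tested in a functional assay on PC-3 cells (Homo sapiens) for antiproliferative activity, read by sulforhodamine B assay, with a stated time of 3 days; a lower number here means that less compound is needed, a higher number that more compound is needed for the effect. Among the three numbers compound 2 stands lowest, so it is the most potent of the set: compound 1 sits at a higher number, and that gap lies beyond the usual scatter, while compound 3 sits further still, again beyond the scatter. Compound 1 and compound 3 differ from compound 2 in several places at once, so no single change can be read from them.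

Compound 4 `CCCC1=C(OC)C(CCC)(CCC)C(=O)/C(=C(O)\C=C\c2ccc(Br)cc2)C1=O` has not yet been measured. It differs from compound 2 in exactly one place: bromo in place of iodo on an aromatic carbon. Going by the values given here, no pair of measured compounds shows this exchange, so there is no measured step to lean on. Replacing one halogen with another on the same aromatic carbon is the kind of change that often leaves a result of this sort nearly unchanged, so the expected step from compound 2 to compound 4 is small and within the scatter, with a slight lean toward a higher number, as a 1.3-fold higher number from compound 2 to compound 4 (0.10 log units; within the scatter) expresses. Compound 4 is therefore estimated at 3.5 uM, with a plausible range from 1.5 uM to 8 uM.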

Compound 4, concentration for half-maximal effect: 4.7 uM
For compound 4 the middle estimate is 1.3-fold (0.13 log units) below the measured one; measured number inside the range.
By their numbers in this assay, from the lowest: compounds 2, 4, 1 and 3 (each within the scatter of the next, the first and the last beyond it).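

In this assay putting bromo in place of iodo on this aromatic carbon gives a 1.7-fold higher number from compound 2 to compound 4 (0.22 log units; within the scatter) and so the two halogens cannot be told apart at this position. Going by these compounds alone, this is the first pair in the set that differs in one place only, which makes it the first direct reading of a single change on the shared core. It shows that on this core the result does not depend on the 4-iodophenyl group specifically, since the 4-bromophenyl group gives a number within the scatter of it. No accompanying measurement offers an explanation for this result.

From the compounds shown here alone, whether a fluoro group, a methoxy group, an amine or a carboxylic acid on the same aromatic carbon would stay within the scatter remains open. Compound 1 and compound 3 carry a plain phenyl ring, but they also differ from compound 2 elsewhere, so the effect of having any halogen at all on this ring cannot be read from them.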